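Changing the aryl group on a highly stable compound

The source may hold more compounds than are shown below. What is called first, only, known or untested is meant among the compounds shown, and "the series" means these compounds.

Measured in an ADME assay on microsomes from liver (Homo sapiens) for metabolic stability, read by LC-MS, using NADPH, with a stated time of 60 min (on this read-out lower numbers stand for a less stable compound and higher numbers for a more stable compound), are three compounds sharing one core. Compound 1 `CC(C)(C)c1sc2ncnc(Oc3ccccc3F)c2c1-c1ccccc1` gives 78%, and compound 2 `CC(C)(C)c1sc2ncnc(Oc3ccccc3F)c2c1-c1ccc(F)cc1` gives 88%. Compound 3 `CC(C)(C)c1sc2ncnc(Oc3ccccc3OC(F)(F)F)c2c1-c1ccc(F)cc1` gives > 95%, which is a limit of the assay and not a number. Compound 3 therefore stands at the limit of > 95% in this assay, at which 1 of the 3 values shown sits.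

Compound 4 `CC(C)(C)c1sc2ncnc(Oc3ccccc3OC(F)(F)F)c2c1-c1ccc(Cl)c(Cl)c1` keeps all of compound 3 except one group: 3,4-dichlorophenyl in place of 4-fluorophenyl (3,4-dichlorophenyl in place of 4-fluorophenyl on an aromatic carbon). The group sits on an aromatic carbon of the five-membered ring with sulfur, next to the ring atom that bears the tert-butyl group.

Among the measured compounds shown here, two measured steps bear on this change. The one on this same aryl group, fluoro in place of hydrogen, gave a number 10 percentage points higher from compound 1 to compound 2 (within the scatter). The other, trifluoromethoxy in place of fluoro, gave a number at least 7 percentage points higher from compound 2 to compound 3 (that floor lies within the scatter). For the measured compounds named here, no measured compound carries chlorine, so these steps offer only a loose guide. With neither step clearly beyond the scatter, no step beyond the scatter is expected here, and the estimated size is a number at least 5 percentage points lower from compound 3 to compound 4 (that floor lies within the scatter). On these data alone, the exact number for compound 3 is unknown, so this estimate is rough. In this assay, the expected value for compound 4 is 90%, with an estimated range from 76% to 98%.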

Compound 4, percent of the compound remaining: > 95%
Compound 4: a limit, no number; the forecaster's own chance of this, stated with the estimate: 35%; middle value at least 5 percentage points away from the limit.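

In this assay compound 4 gives > 95%, which is a limit of the assay and not a number. Compound 3 sits at a limit too, so no step can be read between compound 3 and compound 4: the limit of > 95% in this assay, at which 2 of the 4 values shown sit.

The compounds shown leave open whether 3,4-dichlorophenyl and 4-fluorophenyl differ at all in this assay.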